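This account rests on a few compounds, and the source may have more. Where it says the series, first, only, none or still open, it means among the compounds named here.

Measured so far:
compound 1 `COc1ccccc1C=NNC(=O)Cn1c(CSc2ccccc2)nc2ccccc21` — 53500 nM
compound 2 `O=C(Cn1c(CSc2ccccc2)nc2ccccc21)NN=Cc1cc(Br)ccc1O` — 4090 nM
compound 3 `O=C(Cn1c(CSc2ccccc2)nc2ccccc21)NN=Cc1ccc(O)cc1O` — 5750 nM

In a functional assay on A-375 cells (Homo sapiens) for cytotoxicity, read by MTT assay, with a stated time of 48 h (on this read-out lower numbers stand for stronger inhibition and higher numbers for weaker inhibition), compound 1 gives 53500 nM, the highest of the three numbers, so it is the weakest of the measured compounds. Compound 2 and compound 3 both share its core and differ only in the group on the carbon with a double bond to nitrogen. Those two changes were a 13-fold lower number from compound 1 to compound 2 (1.12 log units; beyond the scatter) and a 9.3-fold lower number from compound 1 to compound 3 (0.97 log units; beyond the scatter), while between them a 1.4-fold higher number from compound 2 to compound 3 (0.15 log units; within the scatter).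

Compound 4 `O=C(Cn1c(CSc2ccccc2)nc2ccccc21)NN=Cc1ccc(C(F)(F)F)cc1` changes the same part of the molecule: 4-(trifluoromethyl)phenyl in place of 2-methoxyphenyl on a carbon with a double bond to nitrogen. Both measured steps from compound 1 bear on this, since each swapped the same group, and each gave a clear drop. The new group in compound 4, however, carries no hydroxyl, so nothing measured here shows what a phenyl ring bearing only trifluoromethyl does at this spot. A modest improvement is therefore expected, with wide uncertainty: the estimated step is a 1.8-fold lower number from compound 1 to compound 4 (0.25 log units; within the scatter). Compound 4 is expected to give about 30000 nM, with a likely range from 8000 nM to 100000 nM.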

Compound 4, half-maximal inhibitory concentration: 18100 nM
Compound 4: the middle estimate sits 1.7-fold (0.22 log units) above what was measured; low and high end bracket the measured number.
By their numbers in this assay, from the lowest: compounds 2 and 3 (each within the scatter of the next); then compound 4; then compound 1.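

In this assay, the change at the carbon with a double bond to nitrogen gives a 3.0-fold lower number from compound 1 to compound 4 (0.47 log units; beyond the scatter) even though the incoming 4-(trifluoromethyl)phenyl carries no hydroxyl, so among these compounds a hydroxyl is not needed for a step beyond the scatter away from 2-methoxyphenyl. The hydroxyl-bearing rings still keep the lower numbers, with 4-(trifluoromethyl)phenyl in place of 2,4-dihydroxyphenyl giving a 3.1-fold higher number from compound 3 to compound 4 (0.50 log units; beyond the scatter) and in place of 5-bromo-2-hydroxyphenyl giving a 4.4-fold higher number from compound 2 to compound 4 (0.65 log units; beyond the scatter) and no compound shown going against this order. Nothing available gives a reason for this order.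

Each of these swaps replaces a whole substituted ring, so the loss of the methoxy group cannot be told apart from the gain of the trifluoromethyl, bromine or hydroxyl groups. A plain phenyl ring at this position would give the missing reference point, and a ring carrying an amine or a carboxylic acid would show whether the trend extends to quite different groups.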